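Aryl-to-alkyl amine change in a cytotoxicity series

The source may hold more compounds than are shown below. What is called first, only, known or untested is meant among the compounds shown, and "the series" means these compounds.

Measured so far:
compound 1 `CCCCCNc1nc(NCc2ccco2)c2cc(F)ccc2n1`: 4100 nM
compound 2 `COc1ccc(Nc2nc(NCc3ccco3)c3cc(F)ccc3n2)cc1`: 6150 nM

In a functional assay on HCT-116 cells (Homo sapiens) for cytotoxicity, read by MTT assay, with a stated time of 2 days (on this read-out lower numbers stand for stronger inhibition and higher numbers for weaker inhibition), compound 2 holds the higher of the two numbers, but its gap to compound 1 lies within the scatter: a 1.5-fold higher number from compound 1 to compound 2 (0.18 log units; within the scatter). Compound 3 `CCCCNc1nc(NCc2ccco2)c2cc(F)ccc2n1` differs from compound 2 by butyl in place of 4-methoxyphenyl on a nitrogen on an aromatic ring. Going by the values given here, the only measured step touching this nitrogen is a 1.5-fold higher number from compound 1 to compound 2 (0.18 log units; within the scatter), which runs from an alkyl chain to the 4-methoxyphenyl and stayed within the scatter; the present change runs the other way, and the butyl rather than pentyl chain is a difference the data do not cover. In this assay no step beyond the scatter is therefore expected for compound 3. Compound 3 is estimated at 4200 nM, with a range from 1700 nM to 10000 nM. This estimate corresponds to an expected step of a 1.5-fold lower number from compound 2 to compound 3 (0.17 log units; within the scatter).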

Compound 3, half-maximal inhibitory concentration: 4310 nM
The estimate for compound 3 lay 1.0-fold (0.01 log units) below the measured number; measured number inside the range.
By their numbers in this assay, from the lowest: compounds 1, 3 and 2 (each within the scatter of the next).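

In this assay, butyl in place of 4-methoxyphenyl on this nitrogen gives a 1.4-fold lower number from compound 2 to compound 3 (0.15 log units; within the scatter) and trimming the pentyl chain to butyl gives a 1.1-fold higher number from compound 1 to compound 3 (0.02 log units; within the scatter) as the second new reading at this position. The nitrogen therefore now carries an aromatic ring and two alkyl chains of different length, and no step among these three compounds leaves the scatter. No supporting data are available to explain this flat picture.

Going by these compounds, whether a much shorter chain, a branched chain or a chain ending in an amine or a carboxylic acid would move the number beyond the scatter remains open. Also open, on these data alone, is whether this flat response holds when the furan-bearing amine or the fluorine on the shared core is replaced.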